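Piperidine for piperazine on the pyridyl amine

The source may hold more compounds than are shown below. What is called first, only, known or untested is meant among the compounds shown, and "the series" means these compounds.

compound 1 `CN1CCN(c2ccc(Nc3ncc4c(n3)N(C3CCCC3)CC(=O)N4)cc2)CC1`: 12200 nM
compound 2 `CN1CCN(c2ccc(Nc3ncc4c(n3)N(C3CCCC3)CC(=O)N4)nc2)CC1`: > 30000 nM

In a functional assay on HCT-116 cells (Homo sapiens) for inhibition, read by MTT assay, with a stated time of 48 h (a lower number here means a stronger inhibitor, a higher number a weaker inhibitor), compound 1 gives 12200 nM. For compound 2 the reading is a limit and not a number, > 30000 nM. Compound 2 therefore stands at the limit of > 30000 nM in this assay, at which 1 of the 2 values shown sits, the weaker end of the two values shown, with no number to anchor it.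

Compound 3, `CC1CCN(c2ccc(Nc3ncc4c(n3)N(C3CCCC3)CC(=O)N4)nc2)CC1`, differs from compound 2 by 4-methylpiperidin-1-yl in place of 4-methylpiperazin-1-yl on an aromatic carbon. For the measured compounds named here, no step between measured compounds connects this change to a number in this assay, so its size is open. Since compound 2 already gives only a limit, the step from compound 2 to compound 3 is expected to be none beyond the scatter, a number no higher from compound 2 to compound 3 (the limit leaves the size open), and the most likely outcome is a further limit. Compound 3 is estimated at 30000 nM, within a range of 10000 nM to 100000 nM.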

Compound 3, half-maximal inhibitory concentration: > 30000 nM
Compound 3 was reported as a limit (the forecaster's own chance of this, stated with the estimate: 65%); the middle value sits exactly at the limit.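

Compound 2 and compound 3 are both reported only as limits, and no step between them can be read in this assay: the limit of > 30000 nM in this assay, at which 2 of the 3 values shown sit.

The compounds shown leave open whether 4-methylpiperidin-1-yl in place of 4-methylpiperazin-1-yl changes the reading in this assay at all, and in which direction.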